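A few compounds are considered here, and "the series" means these few. Any claim that something is new, unique, unknown or untested is made for them only; others in the source may bear on it.

Measured compounds:
Compound 1, `COc1cccc(OC)c1OCCNCCOc1ccccc1OCc1ccccc1Cl` — 5400 nM
Compound 2, `COc1cccc(OC)c1OCCNCCOc1ccccc1OCc1cccc(Cl)c1` — 5900 nM
Compound 3, `COc1cccc(OC)c1OCCNCCOc1ccccc1OCc1ccccc1[N+](=O)[O-]` — 13200 nM

All three numbers come from a functional assay on PC-3 cells (Homo sapiens) for cytotoxicity, read by sulforhodamine B assay; a higher number here means a weaker inhibitor of growth, a lower number a stronger inhibitor of growth. Compound 2 stands second highest of the three: the step of a 1.1-fold higher number from compound 1 to compound 2 (0.04 log units; within the scatter) is within the scatter, so compound 1 and compound 2 cannot be told apart, while the step of a 2.2-fold higher number from compound 2 to compound 3 (0.35 log units; beyond the scatter) is beyond it and marks a modest weakening.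

Compound 4, `COc1ccccc1COc1ccccc1OCCNCCOc1c(OC)cccc1OC`, has not yet been tested in this assay. It differs from compound 2 in one place: 2-methoxyphenyl in place of 3-chlorophenyl on a saturated chain carbon bound to an oxygen on an aromatic ring. Within the data shown here, two measured steps bear on this change, since both alter the group on that same saturated chain carbon bound to an oxygen on an aromatic ring. Moving the chloro from one position of the phenyl to another gave a 1.1-fold higher number from compound 1 to compound 2 (0.04 log units; within the scatter), no change beyond the scatter. Putting 2-nitrophenyl in place of 3-chlorophenyl gave a 2.2-fold higher number from compound 2 to compound 3 (0.35 log units; beyond the scatter), a modest weakening. Among the measured compounds shown here, no measured compound carries a methoxyphenyl at this place, so the direction is uncertain; a step within the scatter or a slight rise in number is expected, as a 1.2-fold higher number from compound 2 to compound 4 (0.07 log units; within the scatter).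

Compound 4 is therefore estimated at 7000 nM, with a likely range from 3500 nM to 15000 nM.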

Compound 4, concentration for 50% growth inhibition: 8900 nM
For compound 4 the middle estimate is 1.3-fold (0.10 log units) below the measured one; the measured number falls inside the stated range.
By their numbers in this assay, from the lowest: compounds 1, 2, 4 and 3 (each within the scatter of the next, the first and the last beyond it).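

In this assay, the 2-methoxyphenyl group on the saturated chain carbon bound to an oxygen on an aromatic ring gives a number that cannot be told apart from any of the earlier three: a 1.5-fold higher number from compound 2 to compound 4 (0.18 log units; within the scatter), a 1.6-fold higher number from compound 1 to compound 4 (0.22 log units; within the scatter) and a 1.5-fold lower number from compound 3 to compound 4 (0.17 log units; within the scatter) all lie within the scatter. Among these compounds, this adds a group with a hydrogen-bond acceptor to a place that had so far held only chlorophenyl and nitrophenyl groups, and compound 4 falls within the scatter of both compound 1 and compound 3, even though those two are separated by a 2.4-fold higher number from compound 1 to compound 3 (0.39 log units; beyond the scatter). The position therefore accepts this change without a clear shift, but nothing measured here explains why.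

The compounds shown leave open whether moving the methoxy group, as in 3-methoxyphenyl, would matter as little as moving the chloro did. They also do not show how a plain phenyl, or a phenyl bearing an amine or a carboxylic acid, would behave at this place.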